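This account rests on a few compounds, and the source may have more. Where it says the series, first, only, none or still open, it means among the compounds named here.

Measured so far in a functional assay on HEK293 cells for agonist activity at D(4) dopamine receptor (Homo sapiens), read by FLIPR; on this read-out lower numbers stand for an effect already at smaller amounts and higher numbers for an effect only at larger amounts of compound:

- compound 1, `Cc1cc(C)cc(NC(=O)CN2CCC(c3cccc[n+]3[O-])CC2)c1`: 52 nM
- compound 2, `c1ccc(C2CCN(Cc3nc4ccccc4[nH]3)CC2)nc1`: 12 nM

Of these two numbers, compound 1 has the higher one; compound 2 reaches its effect at a clearly smaller amount, and the gap between the two lies beyond the usual scatter of this assay. Compound 1 therefore stands as the weaker of the pair on the numbers shown.

Compound 3, `O=C(CN1CCC(c2cccc[n+]2[O-])CC1)Nc1cccc(F)c1`, has not yet been measured in this assay. It differs from compound 1 in a single place: 3-fluorophenyl in place of 3,5-dimethylphenyl on an amide-type nitrogen. The rest of the molecule, including the shared core, is unchanged.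

For the measured compounds named here, no measured pair shows a step of this kind, so there is no direct guide for its size. Both groups are six-membered aromatic rings of carbon only, with neither donors nor acceptors. A modest step is expected from compound 1 to compound 3, most likely within or only slightly beyond the scatter, and if anything toward a higher number. The estimated step is a 1.5-fold higher number from compound 1 to compound 3 (0.19 log units; within the scatter). For compound 3 the expected value in this assay is 80 nM, with a likely range from 20 nM to 320 nM.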

Compound 3, half-maximal effective concentration: 160 nM
Compound 3: the middle estimate sits 2.0-fold (0.30 log units) below what was measured; the measured number falls inside the stated range.
By their numbers in this assay, from the lowest: compound 2; then compound 1; then compound 3.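

In this assay, the group on the amide-type nitrogen proves to matter: the change gives a 3.1-fold higher number from compound 1 to compound 3 (0.49 log units; beyond the scatter), even though both groups are six-membered aromatic rings of carbon only, with no hydrogen-bond donors or acceptors. For the compounds shown here, this is the first step in the set that can be read at this position, and it shows that the read-out responds to a change in this ring while the shared core stays the same. Nothing available here accounts for the size of this step.

The change removes two methyl groups and brings in a fluorine in a single move, so the compounds shown cannot tell how much of the step belongs to each part. A plain phenyl ring, a phenyl ring carrying one methyl group or one chlorine, or a cyclohexyl ring on the same nitrogen would help to separate these parts and show whether an aromatic ring is needed there at all.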